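A few compounds are considered here, and "the series" means these few. Any claim that something is new, unique, unknown or untested is made for them only; others in the source may bear on it.

Measured in a functional assay on MCF7 cells (Homo sapiens) for cytotoxicity, read by MTT assay, with a stated time of 72 h, tested at 1 uM; a lower number here means less inhibition of growth, a higher number more inhibition of growth at the concentration tested:

- compound 1, `N/C(=N\NC(=S)N1CCCCC1)c1ccccn1`: 15.4%
- compound 2, `N/C(=N\NC(=S)N1CCCC1)c1ccccn1`: 45.9%
- compound 3, `Cc1ccnc(/C(N)=N/NC(=S)N2CCCCC2)c1`: 21.2%

Compound 2 differs from compound 1 by one change, (pyrrolidin-1-yl in place of piperidin-1-yl on a thiocarbonyl carbon). In this assay this change gave a number 30.5 percentage points higher from compound 1 to compound 2 (beyond the scatter), a step that lies beyond the scatter. Compound 3 differs from compound 1 in the core, (methyl in place of hydrogen on an aromatic carbon). That difference gave a number 5.8 percentage points higher from compound 1 to compound 3 (within the scatter), which lies within the scatter, so compound 1 and compound 3 cannot be told apart in this assay on these numbers.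

Compound 4, `Cc1ccnc(/C(N)=N/NC(=S)N2CCCC2)c1`, has not yet been measured. It differs from compound 3 by pyrrolidin-1-yl in place of piperidin-1-yl on a thiocarbonyl carbon. Going by the values given here, this is the same change as the one from compound 1 to compound 2, made on the core of compound 3 instead of the core of compound 1; the place around the thiocarbonyl carbon reads the same in both cases. Among the compounds shown, the change occurs two times in all.

For compound 4 the step of a number 28.8 percentage points higher from compound 3 to compound 4 (beyond the scatter) is expected to be of about the same size as the earlier one, because a number 30.5 percentage points higher from compound 1 to compound 2 (beyond the scatter), and because the two cores sit within the scatter of each other, a number 5.8 percentage points higher from compound 1 to compound 3 (within the scatter). The estimate rests on a single earlier instance of the change and on three measured compounds, so the range is kept wide. Compound 4 is therefore expected to give about 50% in this assay, with the likely range from 32% to 68%.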

Compound 4, percent growth inhibition at one concentration: 49%
The estimate for compound 4 lay 1 percentage points above the measured number; measured number inside the range.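

In this assay, pyrrolidin-1-yl in place of piperidin-1-yl on the thiocarbonyl carbon gave a number 27.8 percentage points higher from compound 3 to compound 4 (beyond the scatter), and on the two cores the change behaves alike: the same change on two cores in this assay, a number 30.5 percentage points higher (beyond the scatter) from compound 1 to compound 2 and a number 27.8 percentage points higher (beyond the scatter) from compound 3 to compound 4, 2.7 percentage points apart, within the scatter of two such steps. Methyl in place of hydrogen on an aromatic carbon gave a number 3.1 percentage points higher from compound 2 to compound 4 (within the scatter), leaving the pair indistinguishable in this read-out, and the same holds for this change with piperidin-1-yl in place of pyrrolidin-1-yl: the same change on two cores in this assay, a number 5.8 percentage points higher (within the scatter) from compound 1 to compound 3 and a number 3.1 percentage points higher (within the scatter) from compound 2 to compound 4, 2.7 percentage points apart, within the scatter of two such steps. The change therefore carries over between these two closely related cores, but this rests on one pair of steps at a single tested concentration in one cell line, and it does not show that the step would persist on a core differing by more than a methyl, nor does it explain why the step arises.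

The compounds shown leave open whether other amines on the thiocarbonyl carbon, such as morpholin-4-yl, azepan-1-yl or an open-chain dimethylamino group, would follow pyrrolidin-1-yl or piperidin-1-yl. Also open, on these data alone, is how the step would behave with something other than methyl on the aromatic carbon, for example chlorine, methoxy or a longer alkyl chain.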